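The source may report more compounds than this note shows. Statements on the series, on what has been measured and on what is new or still open speak of the compounds shown alone.

Measured compounds:
- compound 1 `CN(C)CCCCCn1c2c(c3ccccc31)C(=O)c1c[n+]([O-])c3ccccc3c1C2=O`: 370 nM
- compound 2 `O=C1c2c[n+]([O-])c3ccccc3c2C(=O)c2c1c1ccccc1n2CCCCN1CCCCC1`: 230 nM

In a functional assay on SH-SY5Y cells (Homo sapiens) for cytotoxicity, read by MTT assay, with a stated time of 72 h (on this read-out lower numbers stand for stronger inhibition and higher numbers for weaker inhibition), compound 2 gives 230 nM. Only compound 1 stands beside it, at 370 nM, and the two cannot be told apart within the scatter.

Compound 3 `CCCN1CCN(CCCCn2c3c(c4ccccc42)C(=O)c2c[n+]([O-])c4ccccc4c2C3=O)CC1` keeps the core of compound 2 and has 4-propylpiperazin-1-yl in place of piperidin-1-yl on a saturated chain carbon, four bonds along the chain from an aromatic nitrogen.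

Among the compounds with values here, one measured step bears on this, also an exchange of the chain's end group: a 1.6-fold lower number from compound 1 to compound 2 (0.21 log units; within the scatter). It stayed within the scatter, but it is a single step and involves a different group, so it offers only weak guidance. No step beyond the scatter is therefore expected in this assay, and the estimated change is a 1.3-fold higher number from compound 2 to compound 3 (0.12 log units; within the scatter). For compound 3 the expected value is 300 nM, with an estimated range from 100 nM to 900 nM.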

Compound 3, half-maximal inhibitory concentration: 3970 nM
The estimate for compound 3 lay 13-fold (1.12 log units) below the measured number; the whole stated range lies below it.
By their numbers in this assay, from the lowest: compounds 2 and 1 (each within the scatter of the next); then compound 3.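

In this assay, the group at the end of the chain proves able to shift the number well beyond the scatter: 4-propylpiperazin-1-yl in place of piperidin-1-yl gives a 17-fold higher number from compound 2 to compound 3 (1.24 log units; beyond the scatter), whereas the earlier exchange at this place, a 1.6-fold lower number from compound 1 to compound 2 (0.21 log units; within the scatter), stayed within it. The same holds against the dimethylamino end group, with an 11-fold higher number from compound 1 to compound 3 (1.03 log units; beyond the scatter), so compound 3 stands apart from both earlier compounds, which cannot be told apart from each other. Nothing available explains this separation.

The compounds shown leave open whether the step follows the piperazine ring itself or the propyl group carried on it. An unsubstituted piperazin-1-yl or a 4-methylpiperazin-1-yl on the same chain would separate these two parts of the change.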